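Working notes: fused-ring amides, cytotoxicity readout

The compounds below may be only part of what the source reports. "The series", "measured", "known", "first", "only" and "open" are said of these compounds alone.

Measured so far:
compound 1 `Nc1ccc(Nc2c(C(=O)NCc3ccc(F)cc3)nc(Br)c3cccnc23)cc1` — 7000 nM
compound 2 `CS(=O)(=O)NCCCCCCN(c1nc(C(=O)NCc2ccc(F)cc2)c(O)c2ncccc12)S(C)(=O)=O` — 20000 nM

Both were run in a functional assay on MDA-MB-435 cells (Homo sapiens) for cytotoxicity, read by MTT assay, with a stated time of 72 h; on this read-out lower numbers stand for stronger inhibition and higher numbers for weaker inhibition. Compound 1 holds the lower of the two numbers, and the gap to compound 2 lies beyond the usual scatter. For the measured compounds named here, no pair differing in a single place has been measured, so no step size is known from data. Compound 3 `Cc1ccc(S(=O)(=O)Oc2c(C(=O)NCc3ccc(F)cc3)nc(Br)c3cccnc23)cc1` is not yet measured; it differs from compound 1 by ((4-methylphenyl)sulfonyl)oxy in place of (4-aminophenyl)amino on an aromatic carbon. The change is expected to raise the number in this assay, by a step beyond the scatter. The expected step is a 2.6-fold higher number from compound 1 to compound 3 (0.41 log units; beyond the scatter). For compound 3 the estimate is 18000 nM, ranging from 5000 nM to 60000 nM.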

Compound 3, half-maximal inhibitory concentration: > 20000 nM
Compound 3: a limit, no number (the forecaster's own chance of this, stated with the estimate: 15%); middle value at least 1.1-fold (0.04 log units) from the limit.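

On this aromatic carbon, para to a bromo group, ((4-methylphenyl)sulfonyl)oxy in place of (4-aminophenyl)amino gives an at least 2.8-fold higher number from compound 1 to compound 3 (0.45 log units; beyond the scatter) in this assay. For the compounds shown here, this is the only single-place comparison so far, and it shows that the number responds to the group at this position. The reading for compound 3 is a limit and not a number, so the step has a floor but no known size: the limit of > 20000 nM in this assay, at which 1 of the 3 values shown sits.

Which part of the exchanged group carries the step remains open. Also open, from the compounds shown here alone, is where a plain amine or a benzylamino group on this carbon would fall relative to compound 1.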